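Ortho substitution on the pendant aryl ring

The compounds below may be only part of what the source reports. "The series", "measured", "known", "first", "only" and "open" are said of these compounds alone.

Measured so far:
compound 1, `Fc1ccc(-c2cc3c(cn2)ncn3-c2ccc(OC(F)F)cc2)cc1`, 10000 nM
compound 2, `COc1cc(F)ccc1-c1cc2c(cn1)ncn2-c1ccc(OC(F)F)cc1`, 93 nM
compound 3, `Cc1cccc(C)c1-c1cc2c(cn1)ncn2-c1ccc(OC(F)F)cc1`, 980 nM

In a functional assay on HL-60 cells (Homo sapiens) for activation, read by flow cytometry, with a stated time of 4 days (on this read-out lower numbers stand for an effect already at smaller amounts and higher numbers for an effect only at larger amounts of compound), compound 3 stands second highest of the three, a 10-fold lower number from compound 1 to compound 3 (1.01 log units; beyond the scatter) but an 11-fold higher number from compound 2 to compound 3 (1.02 log units; beyond the scatter). The step to the unmeasured compound 4, `Fc1ccc(-c2cc3c(cn2)ncn3-c2ccc(OC(F)F)cc2)c(Cl)c1`, is 2-chloro-4-fluorophenyl in place of 2,6-dimethylphenyl on an aromatic carbon. Among the measured compounds shown here, two measured steps bear on it: a 110-fold lower number from compound 1 to compound 2 (2.03 log units; beyond the scatter), and a 10-fold lower number from compound 1 to compound 3 (1.01 log units; beyond the scatter), both showing that a substituted ring of this kind gives a lower number than the 4-fluorophenyl of compound 1. Compound 4 carries one such substituent and keeps the fluorine of compound 2, so a lower number than compound 3 is expected, a 3.3-fold lower number from compound 3 to compound 4 (0.51 log units; beyond the scatter), though smaller than that of compound 2. The estimate for compound 4 is 300 nM, within 60 nM to 2000 nM.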

Compound 4, half-maximal effective concentration: 90 nM
Beside the measured number, compound 4's estimate is 3.3-fold (0.52 log units) above it; low and high end bracket the measured number.
By their numbers in this assay, from the lowest: compounds 4 and 2 (each within the scatter of the next); then compound 3; then compound 1.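

In this assay a chloro on the pendant ring serves as well as the methoxy of compound 2: the gain is a 110-fold lower number from compound 1 to compound 4 (2.05 log units; beyond the scatter), yet a 1.0-fold lower number from compound 2 to compound 4 (0.01 log units; within the scatter), so the two groups cannot be told apart here. The 2-chloro-4-fluorophenyl also beats the 2,6-dimethylphenyl, with an 11-fold lower number from compound 3 to compound 4 (1.04 log units; beyond the scatter), so carrying a substituent there does not alone set the number. No measurement at hand explains either result. Open remains whether the chloro works without the fluorine, and how an amine or a carboxylic acid in its place would read.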